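The compounds below may be only part of what the source reports. "The series", "measured", "known", "first", "only" and "open" are said of these compounds alone.

Measured so far:
compound 1, `O=S(=O)(c1ccc(F)cc1)c1cnc2cc(F)ccc2c1-c1cccc(F)c1`: 0.95 mL/min
compound 2, `COc1cccc(S(=O)(=O)c2cnc3cc(F)ccc3c2-c2cccc(Cl)c2)c1`: 2.97 mL/min

In an ADME assay on microsomes from liver (Homo sapiens) for metabolic stability, tested at 2.5 uM (a higher number here means faster removal of the compound, a lower number slower removal), compound 2 stands highest of the two numbers; compound 1 gives 0.95 mL/min, a gap beyond the scatter. Within the data shown here, no pair of measured compounds differs in a single place, so no clean step can be read from these two alone.

Compound 3, `COc1cccc(S(=O)(=O)c2cnc3cc(F)ccc3c2-c2cccc(F)c2)c1`, is not yet measured. Against compound 2 the change is fluoro in place of chloro on an aromatic carbon. Compound 1 already carries the 3-fluorophenyl that enters here, but it also differs from compound 2 elsewhere, so its number is only a loose guide.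

A downward step from compound 2 to compound 3 in this assay is expected, of about a 1.6-fold lower number from compound 2 to compound 3 (0.19 log units; within the scatter), close to the edge of the scatter. For compound 3 the estimated value in this assay is 1.9 mL/min, with a range from 0.9 mL/min to 4 mL/min.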

Compound 3, intrinsic clearance in a liver preparation (reported as CLH), per the amount of preparation that the assay uses: 3.36 mL/min
For compound 3 the middle estimate is 1.8-fold (0.25 log units) below the measured one, within the range that was stated.
By their numbers in this assay, from the lowest: compound 1; then compounds 2 and 3 (each within the scatter of the next).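

In this assay, fluoro in place of chloro on an aromatic carbon, meta to a large group, gives a 1.1-fold higher number from compound 2 to compound 3 (0.05 log units; within the scatter) and so does not separate the two halogens at this position. With the 3-fluorophenyl held constant, 3-methoxyphenyl in place of 4-fluorophenyl on the sulfonyl sulfur gives a 3.5-fold higher number from compound 1 to compound 3 (0.55 log units; beyond the scatter) in this assay and marks the sulfonyl substituent as the place where these compounds differ beyond the scatter. No measurement at hand accounts for either step.

As far as these compounds go, whether this aromatic carbon stays equally insensitive with a group other than a halogen, such as a nitrile or an amine, remains open. Also open, from the compounds shown here alone, is whether the step at the sulfonyl sulfur holds with the 3-chlorophenyl in place of the 3-fluorophenyl.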